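Extending the Long Chain of Compound 3

The compounds below may be only part of what the source reports. "The series", "measured", "known", "first", "only" and "open" are said of these compounds alone.

In an ADME assay on A549 cells (Homo sapiens) for cytotoxicity, read by resazurin assay, with a stated time of 48 h (a higher number here means that more compound is tolerated, a lower number that less compound is tolerated), compound 1 (`CCNc1ccc(NC(=O)c2cc(Cl)ccc2O)c(Cl)c1`) gives 30200 nM, compound 2 (`CC(C)Nc1ccc(NC(=O)c2cc(Cl)ccc2O)c(Cl)c1`) gives 11000 nM and compound 3 (`CCCCCCC(C)Nc1ccc(NC(=O)c2cc(Cl)ccc2O)c(Cl)c1`) gives 23500 nM. Compound 3 cannot be told apart from compound 1, while it stands clear of compound 2, with a 2.1-fold higher number from compound 2 to compound 3 (0.33 log units; beyond the scatter). Compound 4 (`CCCCCCCCC(C)Nc1ccc(NC(=O)c2cc(Cl)ccc2O)c(Cl)c1`) has one change: ethyl in place of hydrogen on a saturated chain carbon, seven bonds along the chain from a nitrogen on an aromatic ring. The closest guide is the hexyl change, which gave a 1.3-fold lower number from compound 1 to compound 3 (0.11 log units; within the scatter). The pentyl change was only modest, and the methyl change, with a 2.7-fold lower number from compound 1 to compound 2 (0.44 log units; beyond the scatter), was of similar size. A further ethyl on the chain is therefore not expected to move the number beyond the scatter. The expected change is a 1.2-fold lower number from compound 3 to compound 4 (0.07 log units; within the scatter). Compound 4 is estimated at 20000 nM, within an expected range of 9000 nM to 42000 nM.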

Compound 4, half-maximal cytotoxic concentration: 21900 nM
For compound 4 the middle estimate is 1.1-fold (0.04 log units) below the measured one, within the range that was stated.
By their numbers in this assay, from the lowest: compounds 2, 4, 3 and 1 (each within the scatter of the next, the first and the last beyond it).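

In this assay, ethyl at this far point, seven bonds along the chain from the nitrogen, brings no readable shift, with a 1.1-fold lower number from compound 3 to compound 4 (0.03 log units; within the scatter). Compound 4 also stays within the scatter of both compounds with shorter groups on that nitrogen, with a 1.4-fold lower number from compound 1 to compound 4 (0.14 log units; within the scatter) and a 2.0-fold higher number from compound 2 to compound 4 (0.30 log units; within the scatter). No measurement shown offers an explanation for this result.

On these data alone, it remains open whether a longer chain would keep the number at this level. As far as these compounds go, it is equally open whether an amine or a carboxylic acid at the chain end would move it.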